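Replacing nitro with amino: expected cytotoxicity of compound 3

This account rests on a few compounds, and the source may have more. Where it says the series, first, only, none or still open, it means among the compounds named here.

In an ADME assay on H9 cells (Homo sapiens) for cytotoxicity, read by XTT assay, with a stated time of 6 days (a higher number here means that more compound is tolerated, a lower number that less compound is tolerated), compound 1 `Cc1cc(Br)cc(C)c1Oc1cc(Nc2ccc(C#N)cc2)c(N)cc1N` gives a measured 38400 nM. Compound 2 `Cc1cc(Br)cc(C)c1Oc1ccc([N+](=O)[O-])c(Nc2ccc(C#N)cc2)c1` reaches only a limit of the assay, > 57000 nM. Compound 3 `Cc1cc(Br)cc(C)c1Oc1ccc(N)c(Nc2ccc(C#N)cc2)c1` differs from compound 2 in one place, with amino in place of nitro on an aromatic carbon. For the measured compounds named here, no measured pair shows this change, so the expectation leans on compound 1, which also carries amino on the shared core and gives 38400 nM in this assay. A moderate fall in tolerated concentration is expected an at least 1.9-fold lower number from compound 2 to compound 3 (0.27 log units; that floor lies within the scatter). For compound 3 the estimated value is 30000 nM, within an expected range of 12000 nM to 60000 nM.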

Compound 3, half-maximal cytotoxic concentration: 44600 nM
Compound 3: middle estimate off by 1.5-fold (0.17 log units), on the low side; low and high end bracket the measured number.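

In this assay, amino in place of nitro on this aromatic carbon gives an at least 1.2-fold lower number from compound 2 to compound 3 (0.10 log units; that floor lies within the scatter), so the change is seen only as a floor. Compound 2 stands at a limit of the assay, not at a number: the limit of > 57000 nM in this assay, at which 1 of the 3 values shown sits. Hydrogen in place of amino on the shared core gives a 1.2-fold higher number from compound 1 to compound 3 (0.07 log units; within the scatter), so the further amino group of compound 1 cannot be told apart from the scatter.

From the compounds shown here alone, the true size of the step from nitro to amino stays open. So does whether an acetamide or a dimethylamino group on this carbon would read differently from amino.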